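The source may report more compounds than this note shows. Statements on the series, on what has been measured and on what is new or still open speak of the compounds shown alone.

Measured in an ADME assay on L929 cells (Mus musculus) for cytotoxicity, read by resazurin assay, with a stated time of 72 h; on this read-out lower numbers stand for stronger inhibition and higher numbers for weaker inhibition:
compound 1 `Cc1cccc(C(=O)/C=C/c2ccc3c(c2)B(O)OC3)c1` gives 8.56 ug/mL.
compound 2 `O=C(/C=C/c1ccc2c(c1)B(O)OC2)c1ccc([N+](=O)[O-])cc1` gives > 10 ug/mL, which is a limit of the assay and not a number.
compound 3 `O=C(/C=C/c1ccc2c(c1)B(O)OC2)c1ccc2c(c1)OCCO2` gives 6.8 ug/mL.

Compound 1 stands at the higher of the two numbers that were reached in this assay. Its nearest neighbour is compound 3, and the gap between them lies within the scatter, so no order can be read between those two. Compound 2 stands apart only in that its result is a limit; this is the single case of the limit of > 10 ug/mL in this assay, at which 1 of the 3 values shown sits, among the three values, and it says no more than that.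

Compound 4 `O=C(/C=C/c1ccc2c(c1)B(O)OC2)c1cccc(O)c1` has not been measured. It differs from compound 1 by hydroxy in place of methyl on an aromatic carbon. Among the compounds with values here, no pair of measured compounds differs in only one place, so no measured step gives a size for a change of this kind, and the three known results sit in a narrow band near the top of the scale. The step in this assay from compound 1 to compound 4 is expected to be small, a 1.0-fold lower number from compound 1 to compound 4 (0.00 log units; within the scatter), in no direction beyond the scatter. For compound 4 in this assay a value of about 8.5 ug/mL is expected, with a range from 4.5 ug/mL to 16 ug/mL, and a fair chance that only a limit is reported.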

Compound 4, half-maximal inhibitory concentration: 7.56 ug/mL
Estimate against measurement, compound 4: 1.1-fold (0.05 log units) above; the measured number falls inside the stated range.
By their numbers in this assay, from the lowest: compounds 3, 4 and 1 (each within the scatter of the next). At a limit, above all of these: compound 2.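

Hydroxy in place of methyl on an aromatic carbon, meta to a large group, gives in this assay a 1.1-fold lower number from compound 1 to compound 4 (0.05 log units; within the scatter), and this is the first size for a change in one place in the series. The change from 3-methylphenyl to 3-hydroxyphenyl swaps one carbon for one oxygen and brings in a hydrogen-bond donor and a hydrogen-bond acceptor, yet the read-out does not move beyond the scatter, so at this position this one exchange leaves the cytotoxicity number where it was. Nothing at hand bears on a cause for this outcome.

From the compounds shown here alone, whether an amine, a carboxylic acid or a longer chain such as ethoxy at this position would move the number beyond the scatter stays open, as does whether hydroxy for methyl reads the same on another carbon of this ring. Compound 2 gives > 10 ug/mL, which is a limit and not a number, and steps to it cannot be read, so the upper end of the series has no measured size.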